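Compound 3 and the Step to Compound 4

The source may report more compounds than this note shows. Statements on the series, on what has been measured and on what is new or still open speak of the compounds shown alone.

The measured compounds:
compound 1, `COc1ccc(-c2[nH]c3cc(OC)ccc3c2C=O)cc1`, which gives 160 nM in a functional assay on MCF7 cells (Homo sapiens) for antiproliferative activity, with a stated time of 5 days; on this read-out higher numbers stand for weaker inhibition and lower numbers for stronger inhibition;
compound 2, `COc1ccc(-c2[nH]c3cc(F)ccc3c2C=O)cc1`, which gives 43 nM;
compound 3, `COc1ccc(-c2[nH]c3cc(Cl)ccc3c2C=O)cc1`, which gives 65 nM.

Compound 3 stands second highest of the three numbers. Its nearest neighbour is compound 2, within the scatter, as a 1.5-fold higher number from compound 2 to compound 3 (0.18 log units; within the scatter); its furthest is compound 1, beyond the scatter, as a 2.5-fold lower number from compound 1 to compound 3 (0.39 log units; beyond the scatter).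

Compound 4, `Cc1ccc(-c2[nH]c3cc(Cl)ccc3c2C=O)cc1`, differs from compound 3 in one place: methyl in place of methoxy on an aromatic carbon. Among the compounds with values here, no measured step touches this place. The two steps that reach beyond the scatter, a 3.7-fold lower number from compound 1 to compound 2 (0.57 log units; beyond the scatter) and a 2.5-fold lower number from compound 1 to compound 3 (0.39 log units; beyond the scatter), both concern a substituent elsewhere on the shared core, so they give no direction for the present change. No step beyond the scatter is therefore expected in this assay. Compound 4 is estimated at 65 nM, with a range from 30 nM to 140 nM. This estimate means that no change at the digits printed from compound 3 to compound 4 (within the scatter) is expected.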

Compound 4, half-maximal inhibitory concentration: 37 nM
The estimate for compound 4 lay 1.8-fold (0.24 log units) above the measured number; measured number inside the range.
By their numbers in this assay, from the lowest: compounds 4, 2 and 3 (each within the scatter of the next); then compound 1.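

Within the data shown here, the position para to a large group, on the six-membered aromatic ring of carbon only, is changed here for the first time. In this assay, methyl in place of methoxy gives a 1.8-fold lower number from compound 3 to compound 4 (0.24 log units; within the scatter), so in this one pair, with chloro held constant, the methoxy can give way to methyl without a step beyond the scatter. Nothing available accounts for this result. Going by these compounds, whether the same change holds with fluoro in place of chloro remains open. So does what an amine, a hydroxyl or a longer chain would give at this position.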